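The compounds below may be only part of what the source reports. "The series", "measured", "known", "first", "only" and "open" are said of these compounds alone.

Working notes on the series. In a functional assay on the whole organism with Mus musculus as the target (a lower number here means that less compound is needed, a higher number that more compound is needed for the effect), compound 1 (`Cn1nc(-c2ccc(F)cc2)n(C)c1=S`) gives 1 mg/kg and compound 2 (`Cn1nc(-c2ccccc2F)n(C)c1=S`) gives 0.23 mg/kg. Compound 2 therefore holds the lower of the two numbers, and its gap to compound 1 lies beyond the usual scatter. Compound 3 (`Cn1nc(-c2ccccc2)n(C)c1=S`) has not yet been measured. It differs from compound 2 by hydrogen in place of fluoro on an aromatic carbon. Among the measured compounds shown here, no measured pair isolates this change, so the expectation is weakly grounded. For the measured compounds named here, it rests on compound 2 at 0.23 mg/kg being the lower of only two numbers, which leaves more room for a rise than for a fall. Expected in this assay is a 2.6-fold higher number from compound 2 to compound 3 (0.42 log units; beyond the scatter), a moderate move towards a higher number and beyond the scatter. For compound 3 the estimated value is 0.6 mg/kg, with an expected range of 0.2 mg/kg to 2.2 mg/kg.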

Compound 3, dose for half-maximal effect: 0.13 mg/kg
The estimate for compound 3 lay 4.6-fold (0.66 log units) above the measured number; measured number below the stated range.
By their numbers in this assay, from the lowest: compounds 3 and 2 (each within the scatter of the next); then compound 1.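

In this assay hydrogen and fluoro on the aromatic carbon ortho to a group of 8 heavy atoms are not separated beyond the scatter (a 1.8-fold lower number from compound 2 to compound 3 (0.25 log units; within the scatter)). The same exchange of fluoro for hydrogen starting from compound 1, whose fluoro stands at another place on the ring, gives a step beyond the scatter (a 7.7-fold lower number from compound 1 to compound 3 (0.89 log units; beyond the scatter)), so among these three compounds the outcome of carrying fluoro depends on where it stands. No measurement at hand accounts for this difference between the two places.

Going by these compounds, whether a larger group such as chloro, methoxy or an amine would be accepted on the carbon that carries fluoro in compound 2 remains open. Also open, on these data alone, is how a longer chain such as ethyl would fare in place of either methyl on the shared core.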